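This account rests on a few compounds, and the source may have more. Where it says the series, first, only, none or still open, it means among the compounds named here.

Measured so far in an assay on LtK cells with ATP-sensitive inward rectifier potassium channel 11 (Homo sapiens) as the target; on this read-out lower numbers stand for an effect already at smaller amounts and higher numbers for an effect only at larger amounts of compound:
compound 1 `CCCC(=O)Nc1c(C(O)(C(F)(F)F)C(F)(F)F)ccc2ccccc12`: 131 nM
compound 2 `O=C(Nc1c(C(O)(C(F)(F)F)C(F)(F)F)ccc2ccccc12)C1CC1`: 751 nM
compound 3 `O=C(CC1CCCC1)Nc1c(C(O)(C(F)(F)F)C(F)(F)F)ccc2ccccc12`: 81 nM

Compound 1 gives the second highest of the three numbers; its nearest neighbour is compound 3, a difference within the scatter a 1.6-fold lower number from compound 1 to compound 3 (0.21 log units; within the scatter), while compound 2 stands apart a 5.7-fold higher number from compound 1 to compound 2 (0.76 log units; beyond the scatter).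

Compound 4 `O=C(Nc1c(C(O)(C(F)(F)F)C(F)(F)F)ccc2ccccc12)c1ccccc1` is not yet measured. It differs from compound 1 in one place: phenyl in place of propyl on a carbonyl carbon.

Among the compounds with values here, the step that bears on this is the one to compound 2, also a ring directly on the carbonyl carbon, which gave a 5.7-fold higher number from compound 1 to compound 2 (0.76 log units; beyond the scatter). The step to compound 3, a ring set one chain carbon further out, a 9.3-fold lower number from compound 2 to compound 3 (0.97 log units; beyond the scatter), shows that larger groups need not weaken the number. For compound 4 a modest rise is therefore expected, a 2.3-fold higher number from compound 1 to compound 4 (0.36 log units; beyond the scatter), with an estimated value of 300 nM (range 90 nM to 1000 nM).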

Compound 4, half-maximal effective concentration: 44 nM
For compound 4 the middle estimate is 6.8-fold (0.83 log units) above the measured one, outside the stated range (below it).
By their numbers in this assay, from the lowest: compounds 4, 3 and 1 (each within the scatter of the next, the first and the last beyond it); then compound 2.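

A ring directly on the carbonyl carbon does not by itself raise the number: phenyl gives a 3.0-fold lower number from compound 1 to compound 4 (0.47 log units; beyond the scatter) and so runs opposite to the cyclopropyl of compound 2. The identity of the ring matters at this position, as shown by a 17-fold lower number from compound 2 to compound 4 (1.23 log units; beyond the scatter) in the largest step of the series so far. Phenyl and cyclopentylmethyl cannot be told apart on this read-out, with a 1.8-fold lower number from compound 3 to compound 4 (0.27 log units; within the scatter) as their step.

Nothing available accounts for the difference between phenyl and cyclopropyl. Still open, as far as these compounds go, is how a pyridine ring in place of phenyl, or a fluorine or methoxy group on the phenyl, would read here.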